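The source may hold more compounds than are shown below. What is called first, only, known or untested is meant among the compounds shown, and "the series" means these compounds.

Among the measured compounds shown here, compound 2, `COc1ccc(-c2cc(NC(=O)COCC(=O)N(C)CC(=O)NC(C)(C)C)nc(-c3ccc(OC)cc3)n2)cc1`, gives 19400 nM in an assay on HeLa cells for displacement of a labelled ligand from adenosine receptor A3 (Homo sapiens), read by fluorescence polarization, with a stated time of 30 min (a higher number here means a weaker inhibitor, a lower number a stronger inhibitor), the lower of the two numbers measured so far; compound 1, `COc1ccc(-c2cc(NC(=O)COCC(=O)NCC(=O)NCc3ccccc3)nc(-c3ccc(OC)cc3)n2)cc1`, stands at 185000 nM. For the measured compounds named here, the only measured step, a 9.5-fold lower number from compound 1 to compound 2 (0.98 log units; beyond the scatter), exchanged the whole tail of the chain at once, so it bears only loosely on a smaller exchange at the very end of that tail. Compound 3, `COc1ccc(-c2cc(NC(=O)COCC(=O)N(C)CC(=O)NC3CCCCC3)nc(-c3ccc(OC)cc3)n2)cc1`, differs from compound 2 by cyclohexyl in place of tert-butyl on an amide-type nitrogen. Going by the values given here, no measured pair isolates this exchange, and nothing in the two values points to a direction for it, so the expectation is a step that stays within the usual scatter rather than one beyond it. Compound 3 is therefore estimated at 16000 nM in this assay, with a range from 5000 nM to 50000 nM, which corresponds to an expected step of a 1.2-fold lower number from compound 2 to compound 3 (0.08 log units; within the scatter).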

Compound 3, inhibition constant: 23700 nM
Estimate against measurement, compound 3: 1.5-fold (0.17 log units) below, and the stated range covers the measured number.
By their numbers in this assay, from the lowest: compounds 2 and 3 (each within the scatter of the next); then compound 1.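

In this assay, cyclohexyl in place of tert-butyl on the amide-type nitrogen gives a 1.2-fold higher number from compound 2 to compound 3 (0.09 log units; within the scatter), so this exchange, which the earlier pair could not isolate, shows that the open tert-butyl and the six-membered carbon ring are not told apart at this position. The step of a 7.8-fold lower number from compound 1 to compound 3 (0.89 log units; beyond the scatter) also lies beyond the scatter, so the lower number relative to compound 1 is not confined to the tert-butyl compound, though that step replaces the whole tail at once and cannot say which part of it counts. No measurement on hand explains either step.

The compounds shown leave open whether methyl, phenyl or a group carrying an amine or a carboxylic acid on this nitrogen would stay in the same range. They also leave open how much of the distance from compound 1 belongs to the benzyl group and how much to the methyl on the chain.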